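The compounds below may be only part of what the source reports. "The series", "measured", "known", "first", "only" and "open" are said of these compounds alone.

Measured in a functional assay on MV4-11 cells (Homo sapiens) for inhibition, read by resazurin assay, with a stated time of 72 h; a lower number here means a stronger inhibitor of growth, a higher number a weaker inhibitor of growth:
- compound 1 `O=C1NCCC12CCN(c1c(Cl)cncc1-c1cc[nH]c1)CC2` gives 1050 nM
- compound 2 `Cc1ccc(-c2cncc(Cl)c2N2CCC3(CCNC3=O)CC2)o1` gives 4950 nM
- compound 3 `O=Cc1sccc1-c1cncc(Cl)c1N1CCC2(CCNC2=O)CC1` gives 28700 nM

Compound 3 has the highest number of the three, and its steps to both others lie beyond the scatter. Compound 4 `O=C1NCCC12CCN(c1c(Cl)cncc1-c1cn[nH]c1)CC2` replaces its 2-formylthiophen-3-yl with 1H-pyrazol-4-yl on an aromatic carbon 1H-pyrazol-4-yl in place of 2-formylthiophen-3-yl on an aromatic carbon in the same core. Among the compounds with values here, two measured steps bear on this: the large 27-fold higher number from compound 1 to compound 3 (1.44 log units; beyond the scatter) and the modest 5.8-fold higher number from compound 2 to compound 3 (0.76 log units; beyond the scatter). Of the measured compounds, compound 1 at 1050 nM carries the group most like the entering one, 1H-pyrrol-3-yl, so a large fall in the number is expected in this assay. The expected change is a 19-fold lower number from compound 3 to compound 4 (1.28 log units; beyond the scatter). For compound 4 the estimate is 1500 nM, with an expected range of 400 nM to 6000 nM.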

Compound 4, concentration for 50% growth inhibition: 8520 nM
For compound 4 the middle estimate is 5.7-fold (0.75 log units) below the measured one, outside the stated range (above it).
By their numbers in this assay, from the lowest: compound 1; then compounds 2 and 4 (each within the scatter of the next); then compound 3.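

In (this assay), 1H-pyrazol-4-yl gives a lower number than 2-formylthiophen-3-yl at this position (a 3.4-fold lower number from compound 3 to compound 4 (0.53 log units; beyond the scatter)), but it does not match 1H-pyrrol-3-yl (an 8.1-fold higher number from compound 1 to compound 4 (0.91 log units; beyond the scatter)). Two similar five-membered aromatic rings therefore separate clearly here, whereas 1H-pyrazol-4-yl and 5-methylfuran-2-yl cannot be told apart (a 1.7-fold higher number from compound 2 to compound 4 (0.24 log units; within the scatter)). Nothing available explains these differences. Going by these compounds, what remains open is whether a five-membered aromatic ring is needed here at all, and whether a phenyl ring, an aminomethyl group or a carboxylic acid would match or better compound 1.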